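The source may hold more compounds than are shown below. What is called first, only, known or untested is meant among the compounds shown, and "the series" means these compounds.

Measured compounds:
- compound 1, `CCN(CC)CC(=O)Nc1ccc(-c2nc3cc(C(F)(F)F)ccc3n2C)cc1`: 16000 nM
- compound 2, `O=C(CCl)Nc1ccc(-c2nc3cc(C(F)(F)F)ccc3[nH]2)cc1`: 22000 nM
- compound 3, `CC(=O)Nc1ccc(-c2nc3cc(C(F)(F)F)ccc3[nH]2)cc1`: 53000 nM

In an ADME assay on BHK cells (Mesocricetus auratus) for cytotoxicity, read by MTT assay, with a stated time of 96 h (a lower number here means that less compound is tolerated, a higher number that more compound is tolerated), compound 1 sits at the low end of these three numbers. Its gap to compound 2 is within the usual scatter of the method, so the two cannot be told apart, whereas compound 3 stands clearly higher, beyond the scatter. Going by the values given here, the only step between neighbours that differ in one place is a 2.4-fold higher number from compound 2 to compound 3 (0.38 log units; beyond the scatter), a modest change.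

Compound 4, `Cn1c(-c2ccc(NC(=O)CN3CCN(c4ccccc4)CC3)cc2)nc2cc(C(F)(F)F)ccc21`, is not yet measured. It differs from compound 1 by 4-phenylpiperazin-1-yl in place of diethylamino on a saturated chain carbon bound to a carbonyl carbon. The measured step from compound 2 to compound 3 touches the same place but swaps quite different groups, so it bears on the new change only loosely; it shows that alterations at this place have so far moved this assay only modestly.

In the absence of a closer precedent, compound 4 is expected to stay near compound 1, with a step of a 1.3-fold lower number from compound 1 to compound 4 (0.12 log units; within the scatter) in this assay that is expected to lie within or just beyond the scatter. The estimate for compound 4 is 12000 nM, with a range from 5000 nM to 30000 nM.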

Compound 4, half-maximal cytotoxic concentration: 100000 nM
Compound 4: the middle estimate sits 8.3-fold (0.92 log units) below what was measured, and the stated range ends below it.
By their numbers in this assay, from the lowest: compounds 1 and 2 (each within the scatter of the next); then compounds 3 and 4 (each within the scatter of the next).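

In this assay, the exchange of diethylamino for 4-phenylpiperazin-1-yl on a saturated chain carbon bound to a carbonyl carbon gives a 6.3-fold higher number from compound 1 to compound 4 (0.80 log units; beyond the scatter). Going by these compounds alone, until now, the only step read at this place was the replacement of chloro by hydrogen, so this is the first sign that a change between two amine groups also moves the number beyond the scatter, and that a far bigger group carrying two rings can stand here without lowering the number. Nothing measured on these compounds bears on why the number rises with this exchange.

The compounds shown leave open whether the rise goes with the phenyl ring or with the piperazine ring itself, a question that a 4-methylpiperazin-1-yl or a morpholin-4-yl group at the same place could help to separate. Within the data shown here, also open is whether the same exchange would give a similar step on the core of compound 3, which differs from the core of compound 1, since only one pair of compounds shows this change so far.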